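Adding an Isopropyl Group to a Potent Inhibitor

The compounds below may be only part of what the source reports. "The series", "measured", "known", "first", "only" and "open" are said of these compounds alone.

Four compounds built from the same set of atoms are compared in an assay on microsomes from intestine for inhibition of acyl-CoA:cholesterol acyltransferase (Oryctolagus cuniculus); on this read-out higher numbers stand for weaker inhibition and lower numbers for stronger inhibition. Compound 1 `CC(C)c1cccc(C(C)C)c1NS(=O)(=O)CC(=O)Oc1c(C(C)C)cccc1C(C)C` gives only a limit in this assay: its result of > 1000 nM is a limit of the assay rather than a number. Compound 2 `CC(C)c1cc(C(C)C)c(OC(=O)CS(=O)(=O)Nc2c(C(C)C)cccc2C(C)C)c(C(C)C)c1` differs from compound 1 by isopropyl in place of hydrogen on an aromatic carbon. In this assay compound 2 gives 2800 nM. The step that the limit leaves unreadable from compound 1 to compound 2 cannot be read because of the limit of > 1000 nM in this assay, at which 1 of the 3 values shown sits. Compound 3 `CC(C)c1cccc(C(C)C)c1NC(=O)CS(=O)(=O)Oc1c(C(C)C)cccc1C(C)C` has the same atoms as compound 1 joined differently; the difference between the two cores is not broken down here. In this assay compound 3 gives 7 nM, the lowest of the two numbers, and its gap to compound 2 lies well beyond the usual scatter.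

Compound 4 `CC(C)c1cc(C(C)C)c(OS(=O)(=O)CC(=O)Nc2c(C(C)C)cccc2C(C)C)c(C(C)C)c1` has not yet been measured. It differs from compound 3 by isopropyl in place of hydrogen on an aromatic carbon, the same change that separates compound 1 from compound 2, at a place described in the same words. Among the compounds with values here, because the earlier step is hidden by the limit of > 1000 nM in this assay, at which 1 of the 3 values shown sits, no measured step shows how large this change should be. The expectation rests only on compound 3 and its value 7 nM, and the step of a 3.6-fold higher number from compound 3 to compound 4 (0.55 log units; beyond the scatter) is expected to be modest, with wide uncertainty. Compound 4 is estimated at 25 nM in this assay, between 4 nM and 300 nM.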

Compound 4, half-maximal inhibitory concentration: 7 nM
Estimate against measurement, compound 4: 3.6-fold (0.55 log units) above; the range from low to high includes it.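

In this assay, putting isopropyl in place of hydrogen on an aromatic carbon gives no change at the digits printed from compound 3 to compound 4 (within the scatter), so on this core the two compounds cannot be told apart, even though the added group brings 3 heavy atoms to a place para to a large group. Within the data shown here, that is one readable pair on one core, and it shows only that this change was tolerated there in this read-out, not that it is tolerated on every core. It cannot be said whether the change carries over from the core of compound 1, because the step from compound 1 to compound 2 cannot be read, and so there is no second step to set beside the new one; compound 1 gives only a limit, which is not a number: the limit of > 1000 nM in this assay, at which 1 of the 4 values shown sits.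

The compounds shown carry only hydrogen or isopropyl at this place on the ring, so they leave open what an amine, a carboxylic acid or a longer chain would give there. They also leave open whether the tolerance seen on the core of compound 3 depends on that core, or would appear on the other core too.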